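The compounds below may be only part of what the source reports. "The series", "measured", "known", "first", "only" and "open" are said of these compounds alone.

Series notes, substitution at the amide nitrogen. Compound 1 `C#CCN(CCOC)C(=O)[C@@]1(c2ccsc2)C[C@H]1CN`, compound 2 `C=CCN(CCOC)C(=O)[C@@]1(c2ccsc2)C[C@H]1CN` and compound 3 `C=C(F)CN(C)C(=O)[C@@]1(c2ccsc2)C[C@H]1CN` share one core and differ only in the groups carried on the amide nitrogen. In an in vitro ADME assay on microsomes from liver (Homo sapiens) for metabolic stability (a higher number here means faster removal of the compound, a lower number slower removal), compound 1 gives a limit, < 2.6 mL/min/kg. In this assay compound 2 likewise gives a limit, < 2.6 mL/min/kg. In this assay compound 3 also gives a limit, < 2.6 mL/min/kg. Compound 2 therefore stands where every measured value sits, at the limit of < 2.6 mL/min/kg in this assay, at which 3 of the 3 values shown sit, and no number separates it from the others. Within the data shown here, the one measured step at this position, a step that the two limits leave unreadable from compound 1 to compound 2, is not readable in size, as both its ends are limits. Compound 4 `C#CCN(CC=C)C(=O)[C@@]1(c2ccsc2)C[C@H]1CN` is not yet measured; it differs from compound 2 by ethynyl in place of methoxymethyl on a saturated chain carbon bound to an amide-type nitrogen. The propargyl that enters is already carried by compound 1, whose result is a limit. Among the measured compounds shown here, no measured step bears directly on the exchange of 2-methoxyethyl for propargyl, so no step beyond the scatter is expected in this assay, and the step that the limit leaves unreadable from compound 2 to compound 4 is an estimate only. Compound 4 is expected to give 2 mL/min/kg, within 1 mL/min/kg to 6 mL/min/kg, most likely reported again as a limit.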

Compound 4, clearance: < 2.6 mL/min/kg
Compound 4: no number, only a limit; the forecaster's own chance of this, stated with the estimate: 65%; the middle value does not contradict the limit.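

Among these compounds, compound 4 gives only a limit in this assay, < 2.6 mL/min/kg, so no step from compound 1 or compound 2 to compound 4 can be read. The compounds shown leave open whether the groups on the amide nitrogen differ at all in clearance, with every result at one limit: the limit of < 2.6 mL/min/kg in this assay, at which 4 of the 4 values shown sit.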